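Morpholine in place of cyanophenylamine on the sulfonamide

A few compounds are considered here, and "the series" means these few. Any claim that something is new, unique, unknown or untested is made for them only; others in the source may bear on it.

Compound 3 `CC1(C)C=C(n2ccccc2=O)c2cc(S(=O)(=O)Nc3ccc(C#N)cc3)ccc2O1` gives 263 nM in a functional assay with Rattus norvegicus as the target (a lower number here means that less compound is needed, a higher number that more compound is needed for the effect), the highest of the two single numbers recorded there; its nearest neighbour, compound 1 `CNS(=O)(=O)c1ccc2c(c1)C(n1ccccc1=O)=CC(C)(C)O2`, gives 17.8 nM, while compound 2 `CC1(C)C=C(n2ccccc2=O)c2cc(S(=O)(=O)Nc3ccccc3)ccc2O1` appears with several entries, 3.09 nM; 2 nM (2 entries). Among the measured compounds shown here, the one single-place change measured so far is a 15-fold higher number from compound 1 to compound 3 (1.17 log units; beyond the scatter). Compound 4 `CC1(C)C=C(n2ccccc2=O)c2cc(S(=O)(=O)N3CCOCC3)ccc2O1` differs from compound 3 by morpholin-4-yl in place of (4-cyanophenyl)amino on a sulfonyl sulfur. That measured step bears on this one in part, since the group whose arrival made it is taken away again, and the several entries of compound 2 in this assay, 3.09 nM; 2 nM (2 entries) shows that an anilide without the nitrile gives low numbers. A lower number is expected for compound 4, as the step of an 8.8-fold lower number from compound 3 to compound 4 (0.94 log units; beyond the scatter). Compound 4 is estimated at 30 nM, within 5 nM to 200 nM.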

Compound 4, half-maximal effective concentration: 85.1 nM
For compound 4 the middle estimate is 2.8-fold (0.45 log units) below the measured one; the measured number falls inside the stated range.
By their numbers in this assay, from the lowest: compound 1; then compound 4; then compound 3.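

In this assay, a sulfonyl sulfur carrying morpholin-4-yl, which has no hydrogen-bond donor, still gives a modest improvement over the anilide with the nitrile, with a 3.1-fold lower number from compound 3 to compound 4 (0.49 log units; beyond the scatter). Against methylamino the same group costs ground, with a 4.8-fold higher number from compound 1 to compound 4 (0.68 log units; beyond the scatter), so compound 4 falls between the two earlier compounds. Removing the nitrile-bearing ring therefore does not by itself reach the lowest numbers seen at this position, which belong to the plain anilide: the several entries of compound 2 in this assay, 3.09 nM; 2 nM (2 entries)

From the compounds shown here alone, whether dimethylamino or piperidin-1-yl would give a number nearer that of compound 1 stays open. The share of the morpholine ring oxygen in these steps therefore cannot be read.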